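The compounds below may be only part of what the source reports. "The series", "measured", "known", "first", "only" and "open" are said of these compounds alone.

Measured in a functional assay on SW-620 cells (Homo sapiens) for cytotoxicity, read by sulforhodamine B assay, with a stated time of 48 h; on this read-out higher numbers stand for weaker inhibition and lower numbers for stronger inhibition:
- Compound 1 `C[C@H]1CC[C@@H]2[C@@H](OC(=O)[C@]23CC(c2ccccc2Br)=NO3)[C@]2(C)C(=O)C=C[C@@]12O`: 44000 nM
- Compound 2 `C[C@H]1CC[C@@H]2[C@@H](OC(=O)[C@]23CC(c2ccc(N(C)C)cc2)=NO3)[C@]2(C)C(=O)C=C[C@@]12O`: 5100 nM
- Compound 3 `C[C@H]1CC[C@@H]2[C@@H](OC(=O)[C@]23CC(c2ccc(O)cc2)=NO3)[C@]2(C)C(=O)C=C[C@@]12O`: 89000 nM

Compound 3 has the highest number of the three, which makes it the weakest inhibitor so far. Two measured steps show this: a 2.0-fold higher number from compound 1 to compound 3 (0.31 log units; beyond the scatter) and a 17-fold higher number from compound 2 to compound 3 (1.24 log units; beyond the scatter).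

Compound 4 `COc1cc(C2=NO[C@]3(C2)C(=O)O[C@@H]2[C@H]3CC[C@H](C)[C@]3(O)C=CC(=O)[C@@]23C)ccc1O` keeps everything in compound 3 and makes one change: methoxy in place of hydrogen on an aromatic carbon. This puts methoxy in place of hydrogen on an aromatic carbon, ortho to a hydroxy group.

Among the compounds with values here, no measured pair tests this exact change, so the evidence is indirect. Swapping the group on this aromatic ring has mattered, with a modest 8.6-fold lower number from compound 1 to compound 2 (0.94 log units; beyond the scatter) and a large 17-fold higher number from compound 2 to compound 3 (1.24 log units; beyond the scatter). Those swaps replace a whole substituent, however, whereas compound 4 keeps the hydroxy group and adds to it. In this assay a small move is therefore expected, perhaps to a slightly lower number, and probably none beyond the scatter.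

The expected step is a 1.5-fold lower number from compound 3 to compound 4 (0.17 log units; within the scatter). For compound 4 the estimate is 60000 nM, with an expected range from 20000 nM to 150000 nM.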

Compound 4, half-maximal inhibitory concentration: 88000 nM
The estimate for compound 4 lay 1.5-fold (0.17 log units) below the measured number, within the range that was stated.
By their numbers in this assay, from the lowest: compound 2; then compounds 1, 4 and 3 (each within the scatter of the next, the first and the last beyond it).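

Adding methoxy on the aromatic carbon ortho to a hydroxy group leaves the number where it was in this assay (a 1.0-fold lower number from compound 3 to compound 4 (0.00 log units; within the scatter)), so this position tolerates the added group without any readable change, at least on this hydroxy-bearing ring. The 4-hydroxy-3-methoxyphenyl group of compound 4 also stays within the scatter of the 2-bromophenyl group (a 2.0-fold higher number from compound 1 to compound 4 (0.30 log units; within the scatter)), while the 4-(dimethylamino)phenyl group remains well apart (a 17-fold higher number from compound 2 to compound 4 (1.24 log units; beyond the scatter)). Nothing measured here offers an explanation for these results.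

The compounds shown leave open whether a different group at this place, such as an amine or a carboxylic acid, would shift the number. They also leave open whether methoxy would stay equally silent on a ring carrying dimethylamino instead of hydroxy.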